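Carbon-linked acid chain replacing the ether acid of compound 2

This account rests on a few compounds, and the source may have more. Where it says the series, first, only, none or still open, it means among the compounds named here.

In an assay on CHO cells for displacement of a labelled ligand from prostaglandin E2 receptor EP4 subtype (Mus musculus), read by scintillation counting (a higher number here means a weaker inhibitor, a lower number a stronger inhibitor), compound 1 `O=C(O)/C=C/c1ccc(Cn2cccn2)cc1OCCc1ccc2ccccc2c1` gives 670 nM. Compound 2 `O=C(O)COc1ccc(Cn2cccn2)cc1OCCc1ccc2ccccc2c1` reaches only a limit in this assay, > 10000 nM. Compound 2 thus stands at the limit of > 10000 nM in this assay, at which 1 of the 2 values shown sits, and has no number of its own, so the step of an at least 14-fold higher number from compound 1 to compound 2 (1.17 log units; beyond the scatter) is known only as a lower bound. Compound 3 `O=C(O)CCCc1ccc(Cn2cccn2)cc1OCCc1ccc2ccccc2c1` differs from compound 2 by 3-carboxypropyl in place of carboxymethoxy on an aromatic carbon. Among the measured compounds shown here, the single measured step that bears on this change is the one from the 2-carboxyethenyl group of compound 1 to the carboxymethoxy group of compound 2, and it ran against compound 2. Compound 3 carries an acid again on a chain of carbon rather than through an ether oxygen, so a step back toward the numbers of compound 1 is expected, though the chain is longer. For compound 3 the expected step is an at least 4.0-fold lower number from compound 2 to compound 3 (0.60 log units; beyond the scatter) in this assay. Compound 3 is therefore estimated at 2500 nM, with a range from 600 nM to 10000 nM.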

Compound 3, inhibition constant: 1400 nM
Estimate against measurement, compound 3: 1.8-fold (0.25 log units) above, within the range that was stated.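

In this assay, an acid carried on a chain of carbon at this position gives a measured value again, so the loss seen with carboxymethoxy does not extend to every acid chain here: the change gives an at least 7.1-fold lower number from compound 2 to compound 3 (0.85 log units; beyond the scatter). Compound 2 has a limit and not a number, so that step is only a lower bound: the limit of > 10000 nM in this assay, at which 1 of the 3 values shown sits. The two carbon-linked chains are not equivalent, though the gap between them is modest, with 3-carboxypropyl giving a 2.1-fold higher number from compound 1 to compound 3 (0.32 log units; beyond the scatter).

Going by these compounds, compound 2 and compound 3 differ in both the ether oxygen and chain length, so the share of each in the step remains open. A 3-carboxypropoxy chain would address the oxygen at greater length, and a 2-carboxyethyl chain would separate the double bond of compound 1 from chain length.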